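The source may hold more compounds than are shown below. What is called first, only, known or untested is meant among the compounds shown, and "the series" means these compounds.

In a functional assay on SGC-7901 cells (Homo sapiens) for antiproliferative activity, read by sulforhodamine B assay, with a stated time of 72 h (a lower number here means a stronger inhibitor, a higher number a weaker inhibitor), compound 1 `COc1ccccc1NC(=S)N/N=C/c1ccc2ccccc2n1` gives only > 100000 nM, which is a limit of the assay and not a number. Compound 2 `NC(=S)N/N=C/c1ccc2cccnc2n1` likewise gives the limit > 100000 nM. Compound 3 `NC(=S)N/N=C/c1cc2ccccc2s1` also gives the limit > 100000 nM. Among the compounds with values here, no measured step therefore exists. Compound 4 `Cc1ccc(NC(=S)N/N=C/c2ccc3ccccc3n2)cc1` keeps the core of compound 1 but carries 4-methylphenyl in place of 2-methoxyphenyl on an amide-type nitrogen. Within the data shown here, the only anchor is compound 1 at its limit > 100000 nM, so the expectation stays loose. The expected at least 2.0-fold lower number from compound 1 to compound 4 (0.30 log units; that floor lies within the scatter) in this assay is a modest one towards stronger inhibition, and it may not show at all. For compound 4 the estimated value is 50000 nM, with an expected range from 8000 nM to 100000 nM.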

Compound 4, half-maximal inhibitory concentration: 92900 nM
Estimate against measurement, compound 4: 1.9-fold (0.27 log units) below; measured number inside the range.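

In this assay the change on the amide-type nitrogen yields the first actual number shown, with compound 4 at 92900 nM. Compound 1 gives > 100000 nM, which is a limit of the assay and not a number. The change can therefore be read only as an at least 1.0-fold lower number from compound 1 to compound 4 (0.03 log units; that floor lies within the scatter), and its true size stays unknown: the limit of > 100000 nM in this assay, at which 3 of the 4 values shown sit.

The compounds shown do not separate the loss of the methoxy group from the gain of the methyl group, which an unsubstituted phenyl on that nitrogen would address. From the compounds shown here alone, how an aminophenyl or carboxyphenyl group would read there also remains open.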